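The source may report more compounds than this note shows. Statements on the series, on what has been measured and on what is new or still open speak of the compounds shown alone.

Measured compounds:
compound 1, `COc1ccc(Oc2ccc3c(NCCCNCc4cc(F)ccc4OC)ccnc3c2)cc1`, with 9.28 in a physicochemical assay for acid dissociation
compound 2, `COc1cccc(CNCCCNc2ccnc3cc(-c4ccc(C(F)(F)F)cc4)ccc23)c1O`, with 9.47 in this assay

Of the compounds shown here, two have been measured in this assay. Compound 1 gives 9.28, the lower of the two numbers, while compound 2 gives 9.47; the gap between them lies within the usual scatter, so the two values cannot be told apart. Going by the values given here, no pair of measured compounds differs in a single place, so no measured step is available to guide the next compound.

Compound 3, `COc1ccc(F)cc1CNCCCNc1ccnc2cc(Cc3ccc(F)cc3)ccc12`, has not yet been measured in this assay. It differs from compound 1 as follows: 4-fluorobenzyl in place of 4-methoxyphenoxy on an aromatic carbon. The chain that carries the secondary amine and the benzyl group attached to it are the same in compound 1 and compound 3.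

Because compound 1 gives 9.28 and compound 2, carrying a different group on its core, gives 9.47 within the scatter of that, a step no larger than the scatter is expected in this assay, in either direction. For compound 3 the expected value is 9.3, in a range from 9 to 9.6. The expected step is a number 0.02 log units higher from compound 1 to compound 3 (within the scatter), inside the scatter.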

Compound 3, acid dissociation constant: 9.47
Compound 3: middle estimate off by 0.17 log units, on the low side, and the stated range covers the measured number.
By their numbers in this assay, from the lowest: compounds 1, 2 and 3 (each within the scatter of the next).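

In this assay, going by these compounds alone, putting 4-fluorobenzyl in place of 4-methoxyphenoxy on an aromatic carbon of the shared core gives a number 0.19 log units higher from compound 1 to compound 3 (within the scatter), the first step that can be read at a single place. The group that leaves has 2 hydrogen-bond acceptors and 9 heavy atoms, and the group that enters has 0 hydrogen-bond acceptors and 8 heavy atoms, yet the two compounds cannot be told apart in this read-out, so for this pair the exchange leaves no measurable mark. No independent measurement is available to explain this result.

The compounds shown leave open whether a group of a very different kind at this same position, such as a carboxylic acid or a piperazine, would give a number beyond the scatter of these values. They also leave open what a change elsewhere would do, for example a longer chain in place of the one that carries the secondary amine, which is the same in compound 1 and compound 3.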